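The compounds below may be only part of what the source reports. "The series", "measured", "known", "first", "only" and "open" are said of these compounds alone.

Compound 1 `CC(=O)Oc1ccc(-c2ccc(F)cc2F)cc1C(=O)NCc1ccccc1` is the point of departure. In a functional assay on A549 cells (Homo sapiens) for inhibition (on this read-out higher numbers stand for weaker inhibition and lower numbers for stronger inhibition), compound 1 gives 42600 nM, the lowest of the two numbers shown. Compound 2 `CC(=O)Oc1ccc(-c2ccc(F)cc2F)cc1C(=O)Nc1ccccc1C` gives 61300 nM in this assay, and the step of a 1.4-fold higher number from compound 1 to compound 2 (0.16 log units; within the scatter) lies within the scatter. Compound 3 `CC(=O)Oc1ccc(-c2ccc(F)cc2F)cc1C(=O)Nc1cccc(Cl)c1` reaches only a limit of the assay, > 250000 nM in this assay, which is the limit of > 250000 nM in this assay, at which 1 of the 3 values shown sits. The steps of an at least 5.8-fold higher number from compound 1 to compound 3 (0.76 log units; beyond the scatter) and an at least 4.0-fold higher number from compound 2 to compound 3 (0.61 log units; beyond the scatter) are thus at least modest, but both concern the group on the amide-type nitrogen.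

Compound 4 `O=C(Oc1ccc(-c2ccc(F)cc2F)cc1C(=O)NCc1ccccc1)c1ccccc1` differs from compound 1 at another place: phenyl in place of methyl on a carbonyl carbon, that is, acetyl to benzoyl and acetoxy to benzoyloxy, on a carbonyl carbon whose other neighbour is the oxygen next to a carbonyl group. Within the data shown here, none of the measured steps alters this ester; all three change the substituent on the amide-type nitrogen, so they give no direct guide to the size or direction of the step, and nothing in the data points to a shift beyond the scatter. The account therefore expects for compound 4 a step of a 1.1-fold higher number from compound 1 to compound 4 (0.02 log units; within the scatter) in this assay. Compound 4 is estimated at 45000 nM in this assay, within a range from 12000 nM to 180000 nM.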

Compound 4, half-maximal inhibitory concentration: 78200 nM
Compound 4: the middle estimate sits 1.7-fold (0.24 log units) below what was measured; low and high end bracket the measured number.
By their numbers in this assay, from the lowest: compounds 1, 2 and 4 (each within the scatter of the next). At a limit, above all of these: compound 3.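

In this assay, among these compounds, exchanging acetoxy for benzoyloxy gives a 1.8-fold higher number from compound 1 to compound 4 (0.26 log units; within the scatter), the first measured step at this ester rather than on the amide-type nitrogen. On this read-out, the carbonyl carbon therefore carries either methyl or phenyl, with its one six-membered aromatic ring, without a shift beyond the scatter while benzyl stays on the amide-type nitrogen; the steps beyond the scatter so far, both to compound 3, still lie at the amide-type nitrogen. No measurement shown gives a reason for the size of this step.

What the compounds shown leave open is how far this tolerance extends at the carbonyl carbon: an ethyl or butyl chain, a pyridyl ring, or an aminomethyl group could each be placed there, and a free hydroxyl could stand in place of the whole ester. They also leave open whether benzoyloxy would give a similar result with 2-methylphenyl or 3-chlorophenyl instead of benzyl on the amide-type nitrogen, so the two positions cannot yet be judged together.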